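This account rests on a few compounds, and the source may have more. Where it says the series, first, only, none or still open, it means among the compounds named here.

Three compounds have been measured so far in a functional assay on Molt4/C8 cells (Homo sapiens) for cytotoxicity; a higher number here means a weaker inhibitor, a lower number a stronger inhibitor
- compound 1 `Cc1cccc(C)c1NC(=O)/C=C/C(=O)N1C/C(=C\c2ccccc2)C(=O)/C(=C/c2ccccc2)C1` gives 6600 nM
- compound 2 `O=C(/C=C/C(=O)N1C/C(=C\c2ccc([N+](=O)[O-])cc2)C(=O)/C(=C/c2ccc([N+](=O)[O-])cc2)C1)Nc1ccc(Cl)c(Cl)c1` gives 600 nM
- compound 3 `CC(=O)c1ccc(NC(=O)/C=C/C(=O)N2C/C(=C\c3ccccc3)C(=O)/C(=C/c3ccccc3)C2)cc1` gives 1400 nM

Compound 2 has the lowest number of the three. Compound 3 lies nearest to it and compound 1 furthest, and both gaps are beyond the usual scatter.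

Compound 4 `Cc1ccc(NC(=O)/C=C/C(=O)N2C/C(=C\c3ccc([N+](=O)[O-])cc3)C(=O)/C(=C/c3ccc([N+](=O)[O-])cc3)C2)cc1` differs from compound 2 in one place, with 4-methylphenyl in place of 3,4-dichlorophenyl on an amide-type nitrogen. Among the measured compounds shown here, only one measured step changes a group at this place, namely 4-acetylphenyl in place of 2,6-dimethylphenyl (a 4.7-fold lower number from compound 1 to compound 3 (0.67 log units; beyond the scatter)). That step is modest but beyond the scatter, so a swap here can move the number. However, it involves neither group of the present change, and its two compounds lack the nitro groups of compound 2, so it suggests a size and not a direction.

For the measured compounds named here, no other measured compound carries either group. With compound 2 at the low end of the series (600 nM), a small rise in this assay is expected, smaller than the measured step and possibly no larger than the scatter. The expected step is a 1.7-fold higher number from compound 2 to compound 4 (0.22 log units; within the scatter). For compound 4 the estimated value is 1000 nM, with an expected range from 400 nM to 2500 nM.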

Compound 4, half-maximal inhibitory concentration: 700 nM
Beside the measured number, compound 4's estimate is 1.4-fold (0.15 log units) above it; low and high end bracket the measured number.
By their numbers in this assay, from the lowest: compounds 2, 4 and 3 (each within the scatter of the next, the first and the last beyond it); then compound 1.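

In this assay, replacing 3,4-dichlorophenyl with 4-methylphenyl on the amide-type nitrogen gives a 1.2-fold higher number from compound 2 to compound 4 (0.07 log units; within the scatter), so on the core of compound 2, which carries the nitro groups, the two groups cannot be told apart in this read-out. Among the compounds shown here, the only earlier step at this place, a 4.7-fold lower number from compound 1 to compound 3 (0.67 log units; beyond the scatter), lies beyond the scatter and was measured on a different core, so the new step adds that a swap here does not always produce a readable difference, even when both chlorines leave and a methyl enters. No supporting information is available to explain this result.

The compounds shown leave open whether 4-acetylphenyl and 2,6-dimethylphenyl would differ as they do in compounds 1 and 3 if placed on the core of compound 2, and whether 3,4-dichlorophenyl and 4-methylphenyl would stay indistinguishable on the core of compound 1. They also do not tell how an amine or a carboxylic acid in place of the methyl of compound 4 would read in this assay.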